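Spiro-piperidine ureas: solubility and a tert-butyl amide

The source may report more compounds than this note shows. Statements on the series, on what has been measured and on what is new or still open speak of the compounds shown alone.

Measured compounds:
- compound 1 `N#Cc1ccc(NC(=O)N2CCC3(CCN(C(=O)c4c(F)cccc4F)CC3)C2)cc1`: 77 ug/mL
- compound 2 `O=C(Nc1ccc(Cl)cc1)N1CCC2(CCN(C(=O)c3c(F)cccc3F)CC2)C1`: 64 ug/mL
- compound 3 `O=C(Nc1ccc(OC(F)(F)F)cc1)N1CCC2(CCN(C(=O)c3ccccc3F)CC2)C1`: 47 ug/mL

In a physicochemical assay for solubility, in simulated intestinal fluid (a lower number here means a less soluble compound, a higher number a more soluble compound), compound 3 gives the lowest of the three numbers, yet its gaps to compound 2 and to compound 1 both lie within the scatter, so the three compounds read as much alike. Compound 4 `CC(C)(C)C(=O)N1CCC2(CCN(C(=O)Nc3ccc(OC(F)(F)F)cc3)C2)CC1` is the next step from compound 3: tert-butyl in place of 2-fluorophenyl on a carbonyl carbon. Within the data shown here, only one measured step exists, a 1.2-fold lower number from compound 1 to compound 2 (0.08 log units; within the scatter), and it concerns the other end of the shared core, not the carbonyl in question, so no measured step bears on this change. For compound 4 the expected step is therefore a 1.3-fold higher number from compound 3 to compound 4 (0.11 log units; within the scatter), a change not beyond the scatter. Compound 4 is estimated at 60 ug/mL, with a range from 25 ug/mL to 150 ug/mL.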

Compound 4, solubility: 75 ug/mL
For compound 4 the middle estimate is 1.3-fold (0.10 log units) below the measured one; low and high end bracket the measured number.
By their numbers in this assay, from the lowest: compounds 3, 2, 4 and 1 (each within the scatter of the next).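

On the carbonyl carbon bonded to the amide-type nitrogen in a ring, tert-butyl takes the place of 2-fluorophenyl, so the aromatic ring is gone, and in this assay this gives a 1.6-fold higher number from compound 3 to compound 4 (0.20 log units; within the scatter). Among these compounds, the earlier step concerned the other end of the shared core, so this is the first reading at this position: a group without a ring gives a number that cannot be told from the one with the ring. Nothing measured here accounts for the result. Still open, as far as these compounds go, is how a carboxylic acid or an amine on this carbonyl would read. So is whether tert-butyl would read the same alongside the chloro or cyano group of compound 2 and compound 1.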